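Fluorine on the Fused Core: Solubility Outlook for Compound 4

The source may hold more compounds than are shown below. What is called first, only, known or untested is meant among the compounds shown, and "the series" means these compounds.

Measured compounds:
compound 1, `Cc1ccc([C@H](C)NC(=O)Cn2nnc3ccccc3c2=O)cc1`, 12000 nM in a physicochemical assay for solubility, read by HPLC, in phosphate buffer, with a stated time of 16 h, at pH 6.8; a higher number here means a more soluble compound, a lower number a less soluble compound
compound 2, `Cc1ccc([C@H](C)NC(=O)Cn2nnc3ccccc3c2=O)c(F)c1`, 4500 nM in this assay
compound 3, `Cc1ccc([C@H](C)NC(=O)Cn2nnc3ccc(C)cc3c2=O)cc1`, 3100 nM in this assay

Compound 4, `Cc1ccc([C@H](C)NC(=O)Cn2nnc3c(F)cc(C)cc3c2=O)cc1`, has not yet been measured. It differs from compound 3 by fluoro in place of hydrogen on an aromatic carbon. The same kind of change was made once before: compound 2 differs from compound 1 by fluoro in place of hydrogen on an aromatic carbon, and that gave a 2.7-fold lower number from compound 1 to compound 2 (0.43 log units; beyond the scatter). The two cores differ by methyl in place of hydrogen on an aromatic carbon, and that step gave a 3.9-fold lower number from compound 1 to compound 3 (0.59 log units; beyond the scatter). The surroundings of the new fluoro are not the same: in compound 2 it sits ortho to a large group and meta to a methyl group on a ring that is not fused, whereas in compound 4 it sits ortho to a fused ring, meta to a fused ring and meta to a methyl group. Because of a 2.7-fold lower number from compound 1 to compound 2 (0.43 log units; beyond the scatter), a step of similar size, a 2.4-fold lower number from compound 3 to compound 4 (0.38 log units; beyond the scatter), is expected for compound 4. Compound 4 is therefore estimated at 1300 nM, between 500 nM and 3500 nM.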

Compound 4, solubility: 1500 nM
Estimate against measurement, compound 4: 1.2-fold (0.06 log units) below, and the stated range covers the measured number.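

Fluoro in place of hydrogen on an aromatic carbon gave a 2.1-fold lower number from compound 3 to compound 4 (0.32 log units; beyond the scatter) in this assay and, on the core without the added methyl, a 2.7-fold lower number from compound 1 to compound 2 (0.43 log units; beyond the scatter) in the same direction. This is a shared direction across two pairs only: the fluoro stands on a ring that is not fused in compound 2 but on the fused system in compound 4, so it does not show that one place stands in for the other or that the size would hold on further cores. Nothing shown here accounts for either step. The compounds shown leave open whether fluoro at the place it holds in compound 4 would give a like step on the core of compound 1. Going by these compounds, how a chloro, an amine or a carboxylic acid at that place would read also remains open.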